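The compounds below may be only part of what the source reports. "The series", "measured", "known", "first", "only" and "open" are said of these compounds alone.

Of the compounds shown here, two have been measured so far in a functional assay on HCT-116 cells (Homo sapiens) for cytotoxicity, read by MTT assay, with a stated time of 48 h; on this read-out lower numbers stand for stronger inhibition and higher numbers for weaker inhibition. Compound 1 `Clc1ccnc2cc(OCc3ccccc3)ccc12` gives 2470 nM in this assay. Compound 2 `CN(C)CCCNc1ccnc2cc(OCc3ccc(F)cc3)ccc12` gives 740 nM in this assay, the lower of the two numbers, and its gap to compound 1 lies beyond the usual scatter. The next compound, compound 3 `Fc1ccc(COc2ccc3c(Cl)ccnc3c2)cc1`, differs from compound 2 in one place: chloro in place of (3-(dimethylamino)propyl)amino on an aromatic carbon. The same kind of group, a chloro, is also what compound 1 carries in place of an amino chain, so compound 1 is the closest guide to what compound 3 may do. The step from compound 2 to compound 3 is therefore expected to move the number upward, toward weaker inhibition, by about a 3.4-fold higher number from compound 2 to compound 3 (0.53 log units; beyond the scatter). For compound 3 the estimate in this assay is 2500 nM, with a likely range from 1000 nM to 6000 nM.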

Compound 3, half-maximal inhibitory concentration: 2070 nM
The estimate for compound 3 lay 1.2-fold (0.08 log units) above the measured number, within the range that was stated.
By their numbers in this assay, from the lowest: compound 2; then compounds 3 and 1 (each within the scatter of the next).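

In this assay, replacing the (3-(dimethylamino)propyl)amino chain with chloro at the aromatic carbon opposite the ring nitrogen gives a 2.8-fold higher number from compound 2 to compound 3 (0.45 log units; beyond the scatter) on an otherwise unchanged structure, so within this pair the chain goes with the stronger inhibition. Fluoro in place of hydrogen gives a 1.2-fold lower number from compound 1 to compound 3 (0.08 log units; within the scatter) in the pair that carries chloro at this position, so this single change cannot be told apart from repeat-to-repeat variation. Nothing shown here explains why the chain and chloro differ.

As far as these compounds go, it remains open which part of the chain matters: a plain amino group, a shorter chain ending in dimethylamino, or a morpholine at the chain end would help separate these parts. From the compounds shown here alone, whether fluoro has any effect when the chain is present also stays open.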